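The source may report more compounds than this note shows. Statements on the series, on what has been measured and on what is new or still open speak of the compounds shown alone.

Measured so far:
compound 1 `O=C(CN1CN(c2ccccc2)C2(CCN(C(=O)c3ccc(C4CCCCC4)cc3)CC2)C1=O)N1CCCCC1` — 1100 nM
compound 2 `CC(C)(C)c1ccc(C(=O)N2CCC3(CC2)C(=O)N(CC(=O)NCCN)CN3c2ccccc2)cc1` — 7000 nM

In an assay on HEK293 cells for displacement of a labelled ligand from NPC1-like intracellular cholesterol transporter 1 (Homo sapiens) (on this read-out lower numbers stand for stronger inhibition and higher numbers for weaker inhibition), compound 2 gives the higher of the two numbers, and its gap to compound 1 lies beyond the scatter. Compound 3 `CCOC(=O)C1CCCN(C(=O)CN2CN(c3ccccc3)C3(CCN(C(=O)c4ccc(C(C)(C)C)cc4)CC3)C2=O)C1` differs from compound 2 in one place: 3-(ethoxycarbonyl)piperidin-1-yl in place of (2-aminoethyl)amino on a carbonyl carbon. Among the compounds with values here, no two measured compounds differ in a single place, so no measured step guides this change; the only reference is compound 1, which gives 1100 nM in this assay. A downward step beyond the scatter is expected, a 4.7-fold lower number from compound 2 to compound 3 (0.67 log units; beyond the scatter). Compound 3 is estimated at 1500 nM, with a range from 500 nM to 5000 nM.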

Compound 3, half-maximal inhibitory concentration: 8200 nM
The estimate for compound 3 lay 5.5-fold (0.74 log units) below the measured number; the measured number lies above the stated range.
By their numbers in this assay, from the lowest: compound 1; then compounds 2 and 3 (each within the scatter of the next).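

At this carbonyl carbon, 3-(ethoxycarbonyl)piperidin-1-yl in place of (2-aminoethyl)amino gives in this assay a 1.2-fold higher number from compound 2 to compound 3 (0.07 log units; within the scatter) and so does not separate the two groups. The position thus holds a group of 11 heavy atoms with one six-membered ring and 0 hydrogen-bond donors, or a group of 4 heavy atoms with no ring and 2 hydrogen-bond donors, at numbers within the scatter of each other. No measurement at hand accounts for this result.

From the compounds shown here alone, whether a carboxylic acid in place of the ethyl ester would move the number stays open. Compound 1 differs from compound 2 and compound 3 in more than one place, so its number is tied to no single change.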